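Three Measured Analogues and One Still to Be Tested

A few compounds are considered here, and "the series" means these few. Any claim that something is new, unique, unknown or untested is made for them only; others in the source may bear on it.

Measured in a functional assay on SW480 cells (Homo sapiens) for antiproliferative activity, read by MTT assay, with a stated time of 48 h; a higher number here means a weaker inhibitor, a lower number a stronger inhibitor:
Compound 1, `CCCCCC(CCO)n1cnc2c(N)ncnc21`, gives only a limit of the assay: > 50000 nM.
Compound 2, `CCCCCC(CCO)n1cnc2cncnc21`, gives only a limit of the assay: > 50000 nM.
Compound 3, `CCCCCCC(CCO)n1cnc2c(N)ncnc21`, gives only a limit of the assay: > 50000 nM.

Compound 4, `CCCCCCC(CCO)n1cnc2cncnc21`, has not yet been measured in this assay. It differs from compound 3 by hydrogen in place of amino on an aromatic carbon. The same change, hydrogen in place of amino on an aromatic carbon, separates compound 1 from compound 2 (hydrogen in place of amino on an aromatic carbon), and there it made a step that the two limits leave unreadable from compound 1 to compound 2, because of the limit of > 50000 nM in this assay, at which 3 of the 3 values shown sit. The two cores differ by methyl in place of hydrogen on a saturated chain carbon, six bonds along the chain from an aromatic nitrogen, and that step is equally unreadable: a step that the two limits leave unreadable from compound 1 to compound 3. The step expected here is a step that the limit leaves unreadable from compound 3 to compound 4, which rests on compound 1 and compound 2 sitting together at the limit of > 50000 nM in this assay, at which 3 of the 3 values shown sit. Compound 4 is therefore expected to land at 100000 nM, most likely again reported only as a limit, within a range from 30000 nM to 500000 nM.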

Compound 4, half-maximal inhibitory concentration: > 50000 nM
Compound 4: no number, only a limit; the forecaster's own chance of this, stated with the estimate: 90%; the middle value is on the limit's open side.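

Neither the step from compound 3 to compound 4 nor the step from compound 2 to compound 4 can be read, because all the values stop at the same limit: the limit of > 50000 nM in this assay, at which 4 of the 4 values shown sit.
The compounds shown leave open how strongly any of them inhibits, and whether amino or the added methyl changes that at all.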